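Swapping a fluorophenyl amide for a benzothiophene amide

The source may report more compounds than this note shows. Statements on the series, on what has been measured and on what is new or still open speak of the compounds shown alone.

For the measured compounds named here, compound 2 `CN1[C@@H]2c3[nH]c4ccccc4c3C[C@H]1[C@H](C#N)N1[C@@H](CNC(=O)c3ccc(F)cc3)c3[nH]c4ccccc4c3C[C@@H]21` gives 1370 nM in a functional assay on HT-29 cells (Homo sapiens) for cytotoxicity, read by MTT assay, with a stated time of 72 h (a lower number here means a stronger inhibitor, a higher number a weaker inhibitor), the second highest of the three numbers known so far. Its nearest neighbour is compound 3 `CN1[C@@H]2c3[nH]c4ccccc4c3C[C@H]1[C@H](C#N)N1[C@@H](CNC(=O)c3ccc4ccccc4c3)c3[nH]c4ccccc4c3C[C@@H]21`, which gives 4940 nM, and the furthest is compound 1 `CN1[C@@H]2c3[nH]c4ccccc4c3C[C@H]1[C@H](C#N)N1[C@@H](CN3C(=O)c4ccccc4C3=O)c3[nH]c4ccccc4c3C[C@@H]21`, which gives 80 nM. The step of a 17-fold higher number from compound 1 to compound 2 (1.23 log units; beyond the scatter) is large, while the step of a 3.6-fold higher number from compound 2 to compound 3 (0.56 log units; beyond the scatter) is modest. Compound 4 `CN1[C@@H]2c3[nH]c4ccccc4c3C[C@H]1[C@H](C#N)N1[C@@H](CNC(=O)c3cc4ccccc4s3)c3[nH]c4ccccc4c3C[C@@H]21` differs from compound 2 by 1-benzothiophen-2-yl in place of 4-fluorophenyl on a carbonyl carbon. Going by the values given here, only the step from compound 2 to compound 3 bears on this change, since it likewise replaces 4-fluorophenyl with a larger aromatic group on the carbonyl carbon, and it gave a modest rise. A comparable modest rise is therefore expected, so compound 4 is estimated at 3500 nM in this assay, within 1200 nM to 10000 nM, an expected step of a 2.6-fold higher number from compound 2 to compound 4 (0.41 log units; beyond the scatter).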

Compound 4, half-maximal inhibitory concentration: 640 nM
Compound 4: middle estimate off by 5.5-fold (0.74 log units), on the high side; measured number below the stated range.
By their numbers in this assay, from the lowest: compound 1; then compound 4; then compound 2; then compound 3.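

On this carbonyl carbon, a larger aromatic group need not raise the number: in this assay, 1-benzothiophen-2-yl lowers it (a 2.1-fold lower number from compound 2 to compound 4 (0.33 log units; beyond the scatter)), whereas naphthalen-2-yl raised it. The choice between these two larger groups also matters (a 7.7-fold lower number from compound 3 to compound 4 (0.89 log units; beyond the scatter)), yet the amide remains behind the group on compound 1 (an 8.0-fold higher number from compound 1 to compound 4 (0.90 log units; beyond the scatter)). No available evidence explains these differences.

The compounds shown leave open whether the ring sulfur itself matters. A benzofuran-2-yl group, with oxygen in place of sulfur, would address that on the same carbonyl carbon.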